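Moving the Methoxy Group to 4-Methoxyphenyl on the Amide

The source may hold more compounds than are shown below. What is called first, only, known or untested is meant among the compounds shown, and "the series" means these compounds.

In a functional assay on BXPC-3 cells (Homo sapiens) for inhibition, read by MTT assay (a lower number here means a stronger inhibitor, a higher number a weaker inhibitor), compound 1 `O=C(Nc1ccccc1)c1cc2cnc(Nc3ccc(N4CCNCC4)cn3)nc2n1C1CCCC1`, which carries a phenyl group on the amide-type nitrogen, gives 5120 nM. Compound 2 `COc1ccccc1NC(=O)c1cc2cnc(Nc3ccc(N4CCNCC4)cn3)nc2n1C1CCCC1`, the 2-methoxyphenyl member, gives 4120 nM, and the change is a 1.2-fold lower number from compound 1 to compound 2 (0.09 log units; within the scatter). Compound 3 `COc1cccc(NC(=O)c2cc3cnc(Nc4ccc(N5CCNCC5)cn4)nc3n2C2CCCC2)c1`, the 3-methoxyphenyl member, gives 10500 nM, the highest number of the three. Its two steps are a 2.1-fold higher number from compound 1 to compound 3 (0.31 log units; beyond the scatter) and a 2.5-fold higher number from compound 2 to compound 3 (0.41 log units; beyond the scatter).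

Compound 4 `COc1ccc(NC(=O)c2cc3cnc(Nc4ccc(N5CCNCC5)cn4)nc3n2C2CCCC2)cc1` has not yet been measured. It has 4-methoxyphenyl in place of 3-methoxyphenyl on an amide-type nitrogen. Within the data shown here, no measured step covers this exact change, so the methoxy steps above are the only guide. The largest of them is a 2.5-fold higher number from compound 2 to compound 3 (0.41 log units; beyond the scatter), so a step of similar or smaller size is expected. Its direction is uncertain, but a lower number is more likely, as the other two values both lie below that of compound 3. The expected change is a 1.8-fold lower number from compound 3 to compound 4 (0.24 log units; within the scatter). Compound 4 is estimated at 6000 nM, with an expected range of 2800 nM to 12500 nM.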

Compound 4, half-maximal inhibitory concentration: 8970 nM
Compound 4: middle estimate off by 1.5-fold (0.17 log units), on the low side, and the stated range covers the measured number.
By their numbers in this assay, from the lowest: compounds 2, 1, 4 and 3 (each within the scatter of the next, the first and the last beyond it).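

In this assay, the step to the 4-methoxyphenyl amide is a 1.2-fold lower number from compound 3 to compound 4 (0.07 log units; within the scatter), so the 3-methoxyphenyl and 4-methoxyphenyl members cannot be told apart. Adding methoxy to the phenyl group gives a 1.8-fold higher number from compound 1 to compound 4 (0.24 log units; within the scatter), which also leaves no clear separation, whereas the same addition in the 3-methoxyphenyl member went beyond the scatter. The 4-methoxyphenyl member does separate from the 2-methoxyphenyl member, with a 2.2-fold higher number from compound 2 to compound 4 (0.34 log units; beyond the scatter), so among the three methoxy members the clear differences are those that involve compound 2.

Nothing given here accounts for these differences among the methoxy members. The compounds shown leave open whether a different group on the phenyl ring, such as a chlorine, a hydroxyl or an amine, would move the number further from that of compound 1 than methoxy does.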